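Replacing the pyrrolidine sulfonamide arm with a trifluoromethylsulfonyl group

The compounds below may be only part of what the source reports. "The series", "measured", "known", "first", "only" and "open" are said of these compounds alone.

Of the compounds shown here, three sharing one core have been measured in an ADME assay on MT4 cells (Homo sapiens) for cytotoxicity, read by MTT assay, with a stated time of 5 days; a higher number here means that more compound is tolerated, a lower number that less compound is tolerated. Compound 1 `Cc1cc(C)cc(S(=O)(=O)c2c(C(=O)N[C@H]3CCN(Cc4n[nH]c(=O)n4C)C3)[nH]c3ccc(Cl)cc23)c1` gives 21500 nM. Compound 2 `Cc1cc(C)cc(S(=O)(=O)c2c(C(=O)N[C@H]3CCN(Cc4ccccc4C#N)C3)[nH]c3ccc(Cl)cc23)c1` reaches only the limit of the measurement, > 228000 nM, so no number is known for it. Compound 3 `Cc1cc(C)cc(S(=O)(=O)c2c(C(=O)N[C@H]3CCN(S(C)(=O)=O)C3)[nH]c3ccc(Cl)cc23)c1` gives 29900 nM. Among the two real numbers compound 3 holds the higher one, but the gap to compound 1 is within the scatter of the measurement, as seen in a 1.4-fold higher number from compound 1 to compound 3 (0.14 log units; within the scatter). The large measured steps, an at least 10-fold higher number from compound 1 to compound 2 (1.02 log units; beyond the scatter) and an at least 7.6-fold lower number from compound 2 to compound 3 (0.88 log units; beyond the scatter), all alter the group on the amine nitrogen in the ring.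

Compound 4 `Cc1cc(C)cc(S(=O)(=O)c2c(C(=O)NS(=O)(=O)C(F)(F)F)[nH]c3ccc(Cl)cc23)c1` changes a different place: (trifluoromethyl)sulfonyl in place of 1-(methylsulfonyl)pyrrolidin-3-yl on an amide-type nitrogen. Among the measured compounds shown here, no measured step touches the amide-type nitrogen, so none bears directly on this change, and the expectation must rest on the spread of the known values. Compound 4 is therefore estimated to lie near compound 3, an expected step of a 1.3-fold higher number from compound 3 to compound 4 (0.13 log units; within the scatter), with a wide range. The expected value for compound 4 is 40000 nM, between 12000 nM and 200000 nM.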

Compound 4, half-maximal cytotoxic concentration: 141000 nM
Estimate against measurement, compound 4: 3.5-fold (0.55 log units) below; low and high end bracket the measured number.
By their numbers in this assay, from the lowest: compounds 1 and 3 (each within the scatter of the next); then compound 4. At a limit, above all of these: compound 2.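

The earlier steps shown here all altered the group on the amine nitrogen in the ring, whereas this one shows that the amide-type nitrogen also affects how much compound the cells tolerate: in this assay, (trifluoromethyl)sulfonyl in place of 1-(methylsulfonyl)pyrrolidin-3-yl gives a 4.7-fold higher number from compound 3 to compound 4 (0.67 log units; beyond the scatter). The change removes the five-membered ring and the defined stereocentre, and it brings in three fluorine atoms, all in a single step. Nothing shown explains why the tolerated concentration rises.

The compounds shown cannot separate the loss of the ring from the arrival of the trifluoromethyl group as the source of this step. A phenylsulfonyl group or a simple ethyl chain on the same nitrogen would help to tell these two apart.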